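Inverting the Stereocentre of a Dichlorinated Urea

The source may report more compounds than this note shows. Statements on the series, on what has been measured and on what is new or still open speak of the compounds shown alone.

Compound 3 `C[C@@H](NC(=O)Nc1ccc(Cl)c(Cl)c1)c1ccccc1` is the starting point. In an ADME assay on the whole organism with Oryza sativa as the target, tested at 0.1 uM (a lower number here means a stronger effect, a higher number a weaker effect of the compound at the concentration tested), compound 3 gives 98%, which stands second highest of the three numbers recorded so far, though all three lie within the scatter of one another. Its nearest neighbour is compound 1 `C[C@@H](NC(=O)Nc1cccc(Cl)c1)c1ccccc1`, which in this assay gives 97%; the widest gap separates it from compound 2 `C[C@H](NC(=O)Nc1cccc(Cl)c1)c1ccccc1`, which in this assay gives 103%.

Compound 4 `C[C@H](NC(=O)Nc1ccc(Cl)c(Cl)c1)c1ccccc1` is still to be measured. It is related to compound 3 in one way: the two compounds have the same atoms and bonds and differ only in configuration as drawn: 1 of 1 stereo elements differ; a stereocentre at a saturated chain carbon is drawn R in compound 3 and S in compound 4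

Within the data shown here, one measured step bears directly on this change. Between compound 1 and compound 2 the same inversion of configuration, (the fact that compounds 1 and 2 differ only in the configuration as drawn), produced a number 6 percentage points higher from compound 1 to compound 2 (within the scatter). The other step, adding chloro in place of hydrogen on an aromatic carbon, gave a number 1 percentage points higher from compound 1 to compound 3 (within the scatter), also no movement of note. Among the measured compounds shown here, with the only precedent for inverting the stereocentre staying inside the scatter, no step beyond the scatter is expected in this assay for compound 4. The step from compound 3 to compound 4 is estimated as a number 2 percentage points higher from compound 3 to compound 4 (within the scatter). Compound 4 is therefore expected to give about 100%, within the range 88% to 111%.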

Compound 4, a percentage reported as activity, at one concentration (the size of the read-out at that concentration, not a potency): 98%
Compound 4: middle estimate off by 2 percentage points, on the high side, and the stated range covers the measured number.
By their numbers in this assay, from the lowest: compounds 1, 3, 4 and 2 (each within the scatter of the next).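

Inverting the stereocentre now has a reading on the dichlorinated core as well: in this assay it gave no change at the digits printed from compound 3 to compound 4 (within the scatter), so the change stays within the scatter on both cores, the earlier case being a number 6 percentage points higher from compound 1 to compound 2 (within the scatter). The chloro in place of hydrogen on an aromatic carbon, previously read only with the stereocentre drawn R, has now also been read with it drawn S, where it gave a number 5 percentage points lower from compound 2 to compound 4 (within the scatter), and the two readings agree: the same change on two cores in this assay, a number 1 percentage points higher (within the scatter) from compound 1 to compound 3 and a number 5 percentage points lower (within the scatter) from compound 2 to compound 4, 6 percentage points apart, within the scatter of two such steps. Across compounds 1, 2, 3 and 4, then, neither the configuration at this saturated chain carbon nor this chloro has produced a step beyond the scatter, and the effect of one change does not visibly depend on the other.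

With every step inside the scatter, these compounds cannot show whether configuration or chloro matters at any concentration other than the single one tested. Also open, going by these compounds, is whether an amine or a carboxylic acid in place of a chloro, or a longer chain in place of the methyl group, would move the number beyond the scatter.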